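The source may hold more compounds than are shown below. What is called first, only, known or untested is meant among the compounds shown, and "the series" means these compounds.

Measured so far:
- compound 1 `CCCCCCCOc1cc(CCc2nc(C)c(CC)s2)nc(NCc2cc(Cl)cc(NC(=O)OC(C)C)c2)c1`: in an assay on cells for binding affinity to Neuropeptide Y receptor type 1 (Homo sapiens) (a higher number here means a weaker inhibitor, a lower number a stronger inhibitor), compound 1 gives 72 nM
- compound 2 `CCc1sc(CCc2cc(OC(C)C)cc(NCc3cc(Cl)cc(NC(=O)OC(C)C)c3)n2)nc1C`: in this assay compound 2 gives 12 nM

Compound 1 stands at the highest of the two numbers; its nearest neighbour is compound 2, reached by a 6.0-fold lower number from compound 1 to compound 2 (0.78 log units; beyond the scatter), a change on the oxygen on the aromatic ring from heptyl to isopropyl.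

Compound 3 `CCc1sc(CCc2cc(OC3CCCC3)cc(NCc3cc(Cl)cc(NC(=O)OC(C)C)c3)n2)nc1C` differs from compound 1 at the same place:
cyclopentyl in place of heptyl on an oxygen on an aromatic ring

For the measured compounds named here, the only measured step that bears on this is the one from compound 1 to compound 2, where a shorter branched group on that oxygen gave a lower number beyond the scatter. Cyclopentyl is likewise smaller than heptyl, so a step of roughly the same kind and direction is expected in this assay, written as a 3.6-fold lower number from compound 1 to compound 3 (0.56 log units; beyond the scatter). Whether a ring behaves exactly as isopropyl is not shown by the two compounds at hand, so the range is kept wide. For compound 3 the expected value is 20 nM, with a range from 8 nM to 55 nM.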

Compound 3, half-maximal inhibitory concentration: 11 nM
Compound 3: middle estimate off by 1.8-fold (0.26 log units), on the high side; the range from low to high includes it.
By their numbers in this assay, from the lowest: compounds 3 and 2 (each within the scatter of the next); then compound 1.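

For the compounds shown here, on the oxygen on the aromatic ring, the lower number seen with isopropyl is not specific to that group: in this assay, cyclopentyl in place of heptyl gives a 6.5-fold lower number from compound 1 to compound 3 (0.82 log units; beyond the scatter) and places a ring of carbon only at this position for the first time. Cyclopentyl in place of isopropyl gives a 1.1-fold lower number from compound 2 to compound 3 (0.04 log units; within the scatter), so this assay does not separate the ring from the open branched group, and among these three compounds only the heptyl compound 1 stands apart. Nothing at hand gives a reason for these steps.

Going by these compounds, a straight chain shorter than heptyl, such as butyl, remains open, so chain length cannot yet be separated from branching or ring closure. Also open, on these data alone, is how a chain carrying an amine or a carboxylic acid on this oxygen would read in this assay.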